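The compounds below may be only part of what the source reports. "The series", "measured", "known", "first", "only" and "open" are said of these compounds alone.

Measured so far:
compound 1 `C=CCc1cc(C(C)=O)c(O)cc1OCCCC#N` gives 6% in an assay on isolated protein for binding affinity to leukotriene B4 receptor 1 (Homo sapiens), tested at 1 uM; on this read-out lower numbers stand for less inhibition and higher numbers for more inhibition at the one concentration tested (going by the name of the read-out)
compound 2 `C=CCc1cc(C(C)=O)c(O)cc1OCCCCCCC` gives 8% in this assay
compound 3 `C#CCCCCOc1cc(O)c(C(C)=O)cc1CC=C` gives 29% in this assay

Compound 3 stands highest of the three numbers: the nearest is compound 2, with a number 21 percentage points higher from compound 2 to compound 3 (beyond the scatter), and the furthest is compound 1, with a number 23 percentage points higher from compound 1 to compound 3 (beyond the scatter). Compound 4 `C=CCc1cc(C(C)=O)c(O)cc1OCCCCCC(=O)OC` differs from compound 3 by (methoxycarbonyl)methyl in place of ethynyl on a saturated chain carbon, four bonds along the chain from an oxygen on an aromatic ring. Both steps that raised the number into compound 3 brought a triple bond outside aromatic rings onto that chain, while the step of a number 2 percentage points higher from compound 1 to compound 2 (within the scatter) between two chains without one stayed within the scatter. Taking the ethynyl away again is therefore expected to lower the number by about the same amount, and a number 19 percentage points lower from compound 3 to compound 4 (beyond the scatter) is the step expected here. In this assay compound 4 is estimated at 10%, between 0% and 25%.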

Compound 4, a percentage reported as inhibition, at one concentration (the size of the read-out at that concentration, not a potency): 65%
Compound 4: middle estimate off by 55 percentage points, on the low side, and the stated range ends below it.
By their numbers in this assay, from the lowest: compounds 1 and 2 (each within the scatter of the next); then compound 3; then compound 4.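

In this assay, exchanging ethynyl for (methoxycarbonyl)methyl gives a number 36 percentage points higher from compound 3 to compound 4 (beyond the scatter) and removes the triple bond outside aromatic rings, so compound 4 goes against the earlier link between that bond and a higher number. The chain ending in methoxycarbonyl also exceeds the two chains without a triple bond, with a number 57 percentage points higher from compound 2 to compound 4 (beyond the scatter) and a number 59 percentage points higher from compound 1 to compound 4 (beyond the scatter) in the same read-out. No available evidence bears on why the number rises.

From the compounds shown here alone, it remains open whether the whole methoxycarbonyl group is needed at this position. A carboxylic acid or a primary amide at the chain end, or a longer chain carrying the methoxycarbonyl, would test this.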